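The compounds below may be only part of what the source reports. "The series", "measured", "known", "first", "only" and "open" are said of these compounds alone.

Of the compounds shown here, two with a shared core have been measured. Compound 1, `CNC(=O)c1cc(Oc2ccc(/C=C/c3ccccn3)cc2)ccn1`, carries a methyl group on its amide nitrogen; in a functional assay on A549 cells (Homo sapiens) for antiproliferative activity, read by CCK-8 assay, with a stated time of 48 h (a higher number here means a weaker inhibitor, a lower number a stronger inhibitor), compound 1 gives 17400 nM. Compound 2, `O=C(Nc1ccccc1)c1cc(Oc2ccc(/C=C/c3ccccn3)cc2)ccn1`, carries a phenyl group at the same place, and in this assay compound 2 gives 19100 nM. The step of a 1.1-fold higher number from compound 1 to compound 2 (0.04 log units; within the scatter) shows that swapping methyl for phenyl left the number essentially unchanged, so compound 2 cannot be told apart from compound 1 on these figures.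

Compound 3, `CC(C)NC(=O)c1cc(Oc2ccc(/C=C/c3ccccn3)cc2)ccn1`, differs from compound 2 by isopropyl in place of phenyl on an amide-type nitrogen. Within the data shown here, the only measured step that bears on this position is the one from compound 1 to compound 2, which fell within the scatter. With isopropyl sitting between methyl and phenyl in size, no step beyond the scatter is expected, and a 1.1-fold lower number from compound 2 to compound 3 (0.03 log units; within the scatter) is the estimated change. Compound 3 is therefore expected to give 18000 nM in this assay, most likely between 8000 nM and 40000 nM.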

Compound 3, half-maximal inhibitory concentration: 21400 nM
Compound 3: the middle estimate sits 1.2-fold (0.08 log units) below what was measured, and the stated range covers the measured number.
By their numbers in this assay, from the lowest: compounds 1, 2 and 3 (each within the scatter of the next).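

With compound 3, the amide nitrogen has now carried three different groups, and in this assay the steps of a 1.1-fold higher number from compound 2 to compound 3 (0.05 log units; within the scatter) and a 1.2-fold higher number from compound 1 to compound 3 (0.09 log units; within the scatter) both lie within the scatter. Among these compounds, a branched chain therefore cannot be told apart by these numbers from either the small methyl or the six-membered aromatic ring of phenyl, which is a broader result than the single step between methyl and phenyl could give. Nothing measured here offers an explanation for this flat result.

Methyl, phenyl and isopropyl are all built of carbon alone, so it remains open whether a longer chain ending in an amine or a carboxylic acid would move the number beyond the scatter. From the compounds shown here alone, whether changes elsewhere on the shared core would do so also remains open.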